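Trifluoromethyl in place of hydrogen on compound 2

This account rests on a few compounds, and the source may have more. Where it says the series, first, only, none or still open, it means among the compounds named here.

Measured so far in an ADME assay on MDCKII-LE cells (Canis lupus familiaris) for permeability (on this read-out higher numbers stand for higher permeability and lower numbers for lower permeability), are two compounds:
Compound 1 `Cc1cnc(NC(=O)c2cc(Oc3cnc(C(=O)N(C)C)cn3)c3cc(C)oc3c2)cn1` with 22.3 10^-6 cm/s as its value
Compound 2 `Cc1cc2c(Oc3cnc(C(=O)N(C)C)cn3)cc(C(=O)Nc3cnccn3)cc2o1` with 30 10^-6 cm/s as its value

Within the data shown here, compound 2 stands within the scatter of compound 1, its only measured neighbour. Compound 3 `Cc1cc2c(Oc3cnc(C(=O)N(C)C)cn3)cc(C(=O)Nc3cnc(C(F)(F)F)cn3)cc2o1` is still to be measured. It carries trifluoromethyl in place of hydrogen on an aromatic carbon, turning pyrazin-2-yl into 5-(trifluoromethyl)pyrazin-2-yl (trifluoromethyl in place of hydrogen on an aromatic carbon). Among the measured compounds shown here, no measured compound holds trifluoromethyl. For the measured compounds named here, the only step that bears on the change is hydrogen in place of methyl on an aromatic carbon, which gave a 1.3-fold higher number from compound 1 to compound 2 (0.13 log units; within the scatter) as its result. On that slim evidence, no step beyond the scatter is expected in this assay, and the expected change is a 1.3-fold lower number from compound 2 to compound 3 (0.10 log units; within the scatter) at most a slight one. Compound 3 is estimated at 24 10^-6 cm/s with a range from 12 10^-6 cm/s to 42 10^-6 cm/s in this assay.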

Compound 3, apparent permeability: 9.7 10^-6 cm/s
Compound 3: middle estimate off by 2.5-fold (0.39 log units), on the high side, and the stated range ends above it.
By their numbers in this assay, from the lowest: compound 3; then compounds 1 and 2 (each within the scatter of the next).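

In this assay the carbon two atoms from the ring nitrogen no longer looks indifferent to what it carries: the exchange of methyl and hydrogen had given only a 1.3-fold higher number from compound 1 to compound 2 (0.13 log units; within the scatter) within the scatter, while trifluoromethyl in place of hydrogen gives a 3.1-fold lower number from compound 2 to compound 3 (0.49 log units; beyond the scatter) and so moves the number beyond it. The fall does not depend on hydrogen as the reference, since trifluoromethyl in place of methyl at the same carbon gives a 2.3-fold lower number from compound 1 to compound 3 (0.36 log units; beyond the scatter) as well. Nothing shown here offers an explanation for this fall.

As far as these compounds go, whether it belongs to trifluoromethyl alone or would also follow a chlorine atom, a methoxy group or an amine at this carbon stays open. So does whether a difluoromethyl group would give a step of similar size.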